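The source may hold more compounds than are shown below. What is called first, only, known or untested is meant among the compounds shown, and "the series" means these compounds.

Among the measured compounds shown here, in an ADME assay on MT4 cells (Homo sapiens) for cytotoxicity, read by MTT assay (a lower number here means that less compound is tolerated, a higher number that more compound is tolerated), three compounds on a shared core have numbers so far: compound 1 `Cc1ccc(N(C(=O)c2cc(F)ccc2F)C(=S)OCCN2C(=O)c3ccccc3C2=O)cc1` gives 62000 nM, compound 2 `Cc1ccc(N(C(=O)c2cc(F)cc(F)c2)C(=S)OCCN2C(=O)c3ccccc3C2=O)cc1` gives 54000 nM and compound 3 `Cc1ccc(N(C(=O)c2ccc(Cl)cc2Cl)C(=S)OCCN2C(=O)c3ccccc3C2=O)cc1` gives 49000 nM. Compound 3 therefore stands level with the other two, since a 1.3-fold lower number from compound 1 to compound 3 (0.10 log units; within the scatter) and a 1.1-fold lower number from compound 2 to compound 3 (0.04 log units; within the scatter) both lie within the scatter. Compound 4 `Cc1ccc(N(C(=O)c2ccc([N+](=O)[O-])cc2Cl)C(=S)OCCN2C(=O)c3ccccc3C2=O)cc1` has nitro in place of chloro on an aromatic carbon, so that 2,4-dichlorophenyl becomes 2-chloro-4-nitrophenyl: nitro in place of chloro on an aromatic carbon. For the measured compounds named here, no measured step makes this exact exchange, and no measured compound carries a nitro group. The nearest guides are the changes on the same phenyl group, and a 1.1-fold lower number from compound 1 to compound 2 (0.06 log units; within the scatter) is also within the scatter, like the two steps to compound 3. On that limited evidence, no step beyond the scatter is expected in this assay, and no direction is favoured. The expected step is a 1.1-fold lower number from compound 3 to compound 4 (0.04 log units; within the scatter), which is an estimate only. On these data alone, the estimate for compound 4 is 45000 nM, with an expected range of 20000 nM to 90000 nM, kept wide since the nitro group is untested here.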

Compound 4, half-maximal cytotoxic concentration: 17000 nM
Estimate against measurement, compound 4: 2.6-fold (0.42 log units) above; measured number outside the range, below it.
By their numbers in this assay, from the lowest: compound 4; then compounds 3, 2 and 1 (each within the scatter of the next).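

In this assay, the changes among the fluoro and chloro compounds had all stayed within the scatter, so the phenyl group on the carbonyl had seemed to make little difference. Nitro in place of chloro, para to a large group, is the first change here to go beyond the scatter, with a 2.9-fold lower number from compound 3 to compound 4 (0.46 log units; beyond the scatter), and the comparisons with the two fluorinated compounds agree, with a 3.2-fold lower number from compound 2 to compound 4 (0.50 log units; beyond the scatter) and a 3.6-fold lower number from compound 1 to compound 4 (0.56 log units; beyond the scatter). Compound 4 therefore stands apart from the other three as the one of which less is tolerated, though nothing available here accounts for the step.

On these data alone, it remains open whether this step belongs to the nitro group in particular, or would also appear with a nitrile, an amine or a carboxylic acid at the same place. As far as these compounds go, it is also open whether the step would persist if the remaining chloro group gave way to hydrogen.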